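The compounds below may be only part of what the source reports. "The series", "measured", "known", "first", "only" and "open" are said of these compounds alone.

Compound 1, with the structure `CCC[C@H]1C[C@@H](O)[C@@H](O)C1`, compound 2, `CCCCCC[C@H]1C[C@@H](O)[C@@H](O)C1`, and compound 3, `CN(C)C(=O)/C=C/[C@H]1C[C@@H](O)[C@@H](O)C1`, share a common core and were tested in an ADME assay on S2 cells (Drosophila melanogaster) for cytotoxicity, read by MTT assay; on this read-out lower numbers stand for an effect already at smaller amounts and higher numbers for an effect only at larger amounts of compound. For compound 1 the assay reports only a limit, > 350000 nM. Compound 2 gives 110000 nM. Among the compounds with values here, the one step with both ends known, an at least 3.1-fold lower number from compound 1 to compound 2 (0.50 log units; beyond the scatter), comes with propyl in place of hydrogen on a saturated chain carbon, three bonds along the chain from a saturated ring carbon. For compound 3 the assay again reports only a limit, > 250000 nM. Compound 3 therefore stands at the limit of > 250000 nM in this assay, at which 1 of the 3 values shown sits, and among the three values only compound 2 has an actual number.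

Compound 4, with the structure `CNC(=O)/C=C/[C@H]1C[C@@H](O)[C@@H](O)C1`, differs from compound 3 by hydrogen in place of methyl on an amide-type nitrogen. Within the data shown here, no measured step concerns a change of this kind: the step from compound 1 to compound 2 lengthens a chain on the core and says nothing about an amide-type nitrogen. With the starting value itself a limit, no shift beyond the scatter is expected from this change in this assay. The estimated step that the limit leaves unreadable from compound 3 to compound 4 thus amounts to no real change. Compound 4 is expected to give about 300000 nM, within 120000 nM to 700000 nM, most likely again only a limit.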

Compound 4, half-maximal effective concentration: > 250000 nM
Compound 4: no number, only a limit; the forecaster's own chance of this, stated with the estimate: 65%; the middle value is on the limit's open side.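

In this assay, compound 3 and compound 4 each give only a limit of the assay rather than a number, so the size of the step between compound 3 and compound 4 cannot be read. The compounds shown leave open whether hydrogen in place of methyl on an amide-type nitrogen changes this read-out at all.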